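Acetyl on the phenol oxygen in an indolyl triazolyl coumarin series

The source may report more compounds than this note shows. Statements on the series, on what has been measured and on what is new or still open speak of the compounds shown alone.

The two measured compounds share a core that carries a triazole joined to a second aromatic ring. Compound 1 `CC(=O)Oc1ccc2cc(-n3cc(-c4ccccc4)nn3)c(=O)oc2c1C` bears an acetoxy group and a phenyl on the triazole; in a functional assay on MCF7 cells (Homo sapiens) for antiproliferative activity (on this read-out lower numbers stand for stronger inhibition and higher numbers for weaker inhibition), compound 1 gives 40800 nM. Compound 2 `Cc1c(O)ccc2cc(-n3cc(-c4cc5ccccc5[nH]4)nn3)c(=O)oc12` bears a free hydroxy group and an indolyl on the triazole; in this assay compound 2 gives 38300 nM. Compound 2 thus stands alongside compound 1, the two numbers lying within the usual scatter of each other, so nothing separates them.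

Compound 3 `CC(=O)Oc1ccc2cc(-n3cc(-c4cc5ccccc5[nH]4)nn3)c(=O)oc2c1C` is not yet measured. It differs from compound 2 in one place: acetyl in place of hydrogen on an oxygen on an aromatic ring. Compound 1 already carries this acetoxy group, and its number in this assay does not part from that of compound 2, so the data give no sign that the acetyl alters the read-out. The step of a 1.0-fold higher number from compound 2 to compound 3 (0.02 log units; within the scatter) is therefore expected to stay within the scatter, with no clear direction. Compound 3 is expected to give 40000 nM in this assay, in a range from 15000 nM to 120000 nM.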

Compound 3, half-maximal inhibitory concentration: 76100 nM
Compound 3: middle estimate off by 1.9-fold (0.28 log units), on the low side, and the stated range covers the measured number.
By their numbers in this assay, from the lowest: compounds 2, 1 and 3 (each within the scatter of the next).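

In this assay the hydroxy to acetoxy change can now be read directly on a matched pair carrying the indolyl group (a 2.0-fold higher number from compound 2 to compound 3 (0.30 log units; within the scatter)), and on this pair acetyl in place of hydrogen on an oxygen on an aromatic ring does not separate the two compounds. For the compounds shown here, the same result gives the first direct reading of the other single change, 1H-indol-2-yl in place of phenyl on an aromatic carbon, with the acetoxy group held constant (a 1.9-fold higher number from compound 1 to compound 3 (0.27 log units; within the scatter)), and this step also stays within the scatter. Neither step can be explained from what is available, as no supporting measurement bears on these numbers.

The compounds shown leave open whether a different group on this oxygen, such as a methyl ether or a longer acyl chain like butanoyl, would part from the free hydroxy group. They also leave open whether an amine or a carboxylic acid in place of the indolyl or phenyl ring would shift the number beyond the scatter.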